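This account rests on a few compounds, and the source may have more. Where it says the series, first, only, none or still open, it means among the compounds named here.

Of the compounds shown here, three have been measured in a functional assay on SK-MEL-5 cells (Homo sapiens) for inhibition, read by sulforhodamine B assay, with a stated time of 48 h; on this read-out higher numbers stand for weaker inhibition of growth and lower numbers for stronger inhibition of growth. Compound 2 `COc1cc(-c2cc(/C=C/C(=O)c3ccc(N)cc3)[nH]n2)cc(OC)c1OC` gives 3060 nM, the lowest of the three numbers; compound 3 `COc1ccc(C(=O)/C=C/c2cc(-c3cc(OC)c(OC)c(OC)c3)n[nH]2)cc1` gives 3240 nM, which lies within the scatter of it, while compound 1 `COc1ccc(-c2cc(/C=C/C(=O)c3ccc(N)cc3)[nH]n2)cc1` gives 9250 nM, a gap beyond the scatter. Going by the values given here, the only single-point step measured, a 1.1-fold higher number from compound 2 to compound 3 (0.02 log units; within the scatter), concerns the other ring and does not bear on the change at hand. Compound 4 `COc1ccc(-c2cc(/C=C/C(=O)c3ccc(N)cc3)[nH]n2)cc1OC` differs from compound 2 by hydrogen in place of methoxy on an aromatic carbon. Among the compounds with values here, no such step has been measured; compound 1 and compound 2 differ in the methoxy groups on that ring, and compound 4 sits between them. Compound 4 is therefore expected to fall between the two, a 1.6-fold higher number from compound 2 to compound 4 (0.21 log units; within the scatter). Compound 4 is estimated at 5000 nM in this assay, with a range from 2000 nM to 12000 nM.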

Compound 4, concentration for total growth inhibition: 11500 nM
The estimate for compound 4 lay 2.3-fold (0.36 log units) below the measured number; measured number inside the range.
By their numbers in this assay, from the lowest: compounds 2 and 3 (each within the scatter of the next); then compounds 1 and 4 (each within the scatter of the next).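

On the ring of compound 2, hydrogen in place of the methoxy ortho to a methoxy group weakens growth inhibition in this assay, with a 3.8-fold higher number from compound 2 to compound 4 (0.57 log units; beyond the scatter). Yet methoxy in place of hydrogen on the ring of compound 1 stays within the scatter, with a 1.2-fold higher number from compound 1 to compound 4 (0.09 log units; within the scatter), so among these compounds only the full set of three methoxy groups stands apart from the others. Nothing shown accounts for this difference. The compounds shown leave open whether a hydroxyl, an ethoxy or a fluorine at this position would match methoxy.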